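A few compounds are considered here, and "the series" means these few. Any claim that something is new, unique, unknown or untested is made for them only; others in the source may bear on it.

Working notes on the series. Compound 1 `CCCCCCCCNC(=O)[C@@H](NC(=O)c1ccco1)[C@@H](C)O` is the reference; in a functional assay on MCF7 cells (Homo sapiens) for cytotoxicity, read by MTT assay, with a stated time of 48 h (on this read-out lower numbers stand for stronger inhibition and higher numbers for weaker inhibition), compound 1 gives 91800 nM. Compound 2 `CCCCCCCCNC(=O)[C@@H](NC(=O)c1cccs1)[C@@H](C)O` differs from it by thiophen-2-yl in place of furan-2-yl on a carbonyl carbon and in this assay compound 2 gives 72500 nM; the step is a 1.3-fold lower number from compound 1 to compound 2 (0.10 log units; within the scatter). Compound 3 `CCCCCCCCCCCCCCCCCCNC(=O)[C@@H](NC(=O)c1ccco1)[C@@H](C)O` differs from compound 1 by decyl in place of hydrogen on a saturated chain carbon, eight bonds along the chain from an amide-type nitrogen and in this assay compound 3 gives 21400 nM; the step is a 4.3-fold lower number from compound 1 to compound 3 (0.63 log units; beyond the scatter). Compound 4 `CCCCCCCCCCCCCCCCCCNC(=O)[C@@H](NC(=O)c1cccs1)[C@@H](C)O` has not been measured. It differs from compound 3 by thiophen-2-yl in place of furan-2-yl on a carbonyl carbon, the same change, at the same place, as that from compound 1 to compound 2, which gave a 1.3-fold lower number from compound 1 to compound 2 (0.10 log units; within the scatter). The expected step is a 1.3-fold lower number from compound 3 to compound 4 (0.10 log units; within the scatter). This rests on the earlier step of a 1.3-fold lower number from compound 1 to compound 2 (0.10 log units; within the scatter) applied to compound 3 at 21400 nM. Compound 4 is therefore estimated in this assay at 17000 nM, expected between 8000 nM and 40000 nM.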

Compound 4, half-maximal inhibitory concentration: 25700 nM
Beside the measured number, compound 4's estimate is 1.5-fold (0.18 log units) below it; the range from low to high includes it.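

In this assay, thiophen-2-yl in place of furan-2-yl gives a 1.2-fold higher number from compound 3 to compound 4 (0.08 log units; within the scatter), so the change carries from the core of compound 1 to the core of compound 3 without a detectable difference: the same change on two cores in this assay, a 1.3-fold lower number (0.10 log units; within the scatter) from compound 1 to compound 2 and a 1.2-fold higher number (0.08 log units; within the scatter) from compound 3 to compound 4, 1.5-fold (0.18 log units) apart, within the scatter of two such steps. The chain extension on the thiophen-2-yl pair gives a 2.8-fold lower number from compound 2 to compound 4 (0.45 log units; beyond the scatter), and its size also holds across the two cores: the same change on two cores in this assay, a 4.3-fold lower number (0.63 log units; beyond the scatter) from compound 1 to compound 3 and a 2.8-fold lower number (0.45 log units; beyond the scatter) from compound 2 to compound 4, 1.5-fold (0.18 log units) apart, within the scatter of two such steps. Going by these compounds alone, this shows that the two changes combine consistently across these compounds, but with only two pairs for each change, it does not show that either step would transfer to other cores.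

Still open, on these data alone, is whether a phenyl group on the carbonyl carbon would leave the number unchanged as these two rings do. Also open, as far as these compounds go, is how a dodecyl or longer chain on the amide-type nitrogen would compare.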